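The source may report more compounds than this note shows. Statements on the series, on what has been measured and on what is new or still open speak of the compounds shown alone.

Three compounds of this series have numbers in a functional assay on PC-3 cells (Homo sapiens) for cytotoxicity, read by sulforhodamine B assay, tested at 10 uM; on this read-out lower numbers stand for less inhibition and higher numbers for more inhibition at the one concentration tested (going by the name of the read-out). Compound 1 `CC(=O)OC[C@H]1O[C@@H](n2cc(-c3cn(Cc4ccccc4)nn3)c(=O)[nH]c2=O)C[C@@H]1OC(C)=O` gives 92.1% in this assay. Compound 3 `CC(=O)OC[C@H]1O[C@@H](n2cc(-c3cn(Cc4ccc(C(C)(C)C)cc4)nn3)c(=O)[nH]c2=O)C[C@@H]1OC(C)=O` differs from compound 1 by tert-butyl in place of hydrogen on an aromatic carbon; in this assay compound 3 gives 90.4%, and the step of a number 1.7 percentage points lower from compound 1 to compound 3 (within the scatter) stays within the scatter. Compound 2 `CCCCCCCCc1cc(-c2cn([C@H]3C[C@H](O)[C@@H](CO)O3)c(=O)[nH]c2=O)on1` gives 77.3% in this assay, the lowest of the three numbers; compound 3 is its nearest neighbour and compound 1 its furthest, and both gaps lie beyond the scatter.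

Compound 4 `CC(C)(C)c1ccc(-c2cc(-c3cn([C@H]4C[C@H](O)[C@@H](CO)O4)c(=O)[nH]c3=O)on2)cc1` is not yet measured. It differs from compound 2 by 4-(tert-butyl)phenyl in place of octyl on an aromatic carbon. Among the compounds with values here, only one measured step touches the entering group: a number 1.7 percentage points lower from compound 1 to compound 3 (within the scatter) put tert-butyl onto an aromatic carbon and stayed within the scatter, but that step replaced a hydrogen, not an octyl chain, and no measured pair shows an octyl chain exchanged for an aromatic group on the five-membered aromatic ring with 1 nitrogen and 1 oxygen. The step to compound 4 is therefore expected as a number 4.7 percentage points higher from compound 2 to compound 4 (within the scatter), a change that may stay within the scatter or lean upward only modestly. The estimate for compound 4 in this assay is 82%, with a range from 65% to 93%.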

Compound 4, a percentage reported as inhibition, at one concentration (the size of the read-out at that concentration, not a potency): 87.9%
The estimate for compound 4 lay 5.9 percentage points below the measured number; low and high end bracket the measured number.
By their numbers in this assay, from the lowest: compound 2; then compounds 4, 3 and 1 (each within the scatter of the next).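

In this assay, within the data shown here, the step of a number 10.6 percentage points higher from compound 2 to compound 4 (beyond the scatter) is the first measured change at this position, on an aromatic carbon of the five-membered aromatic ring with 1 nitrogen and 1 oxygen, next to the ring nitrogen, and it lies beyond the scatter. It shows that this position accepts 4-(tert-butyl)phenyl, with its six-membered aromatic ring of carbon only, in place of the open octyl chain, and that the number moves up rather than down with this exchange. Nothing measured in this series accounts for the size of the step.

Open, on these data alone, is whether a plain phenyl, a shorter or longer alkyl chain, or a phenyl carrying an amine or a carboxylic acid would keep, raise or lower the number at this position, and so how much of the step belongs to the ring and how much to the tert-butyl group. Also open, as far as these compounds go, is what the step means for potency, since this assay gives the size of the inhibition at a single concentration and no concentration-response data stand beside it.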